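Adding Chloro to the Benzyl Group of Compound 3

The source may report more compounds than this note shows. Statements on the series, on what has been measured and on what is new or still open speak of the compounds shown alone.

Measured compounds:
compound 1, `COc1ccc(C2N=C(SCc3ccc(Cl)cc3)NC(C)=C2C(=O)Nc2ccc(F)cc2)cc1OC`, 31.3%
compound 2, `CC1=C(C(=O)Nc2ccc([N+](=O)[O-])cc2)C(c2ccc(Br)cc2)N=C(SCc2ccccc2)N1`, 29.7%
compound 3, `CC1=C(C(=O)Nc2ccc([N+](=O)[O-])cc2)C(c2cccc([N+](=O)[O-])c2)N=C(SCc2ccccc2)N1`, 25.6%

All three were tested in a functional assay on the whole organism (artery, strain albino) with Rattus norvegicus as the target, with a stated time of 300 min, at a dose of 10 mg/kg by the oral route; a lower number here means less inhibition, a higher number more inhibition at the dose given (going by the name of the read-out). Compound 3 gives the smallest of the three numbers, but the gap to compound 2, a number 4.1 percentage points lower from compound 2 to compound 3 (within the scatter), and the gap to compound 1 both lie within the scatter, so the three compounds cannot be told apart on these readings.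

Compound 4, `CC1=C(C(=O)Nc2ccc([N+](=O)[O-])cc2)C(c2cccc([N+](=O)[O-])c2)N=C(SCc2cccc(Cl)c2)N1`, has not been measured. It differs from compound 3 in one place: chloro in place of hydrogen on an aromatic carbon. Going by the values given here, no measured step touches this part of the molecule; the only step available, a number 4.1 percentage points lower from compound 2 to compound 3 (within the scatter), changes the group on the saturated ring carbon, not the benzylsulfanyl group, and it stayed within the scatter. Compound 1 carries a chlorobenzyl group and gives 31.3%, but it differs from compound 3 in several other places at once, so it shows only that a chloro there is compatible with a number of the same size.

The expected step is therefore a number 1.4 percentage points higher from compound 3 to compound 4 (within the scatter), no change beyond the scatter. Compound 4 is estimated at 27%, between 15% and 40%.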

Compound 4, a percentage reported as inhibition, in the whole organism at one dose (the size of the read-out at that dose, not a potency): 21%
The estimate for compound 4 lay 6 percentage points above the measured number, within the range that was stated.
By their numbers in this assay, from the lowest: compounds 4, 3, 2 and 1 (each within the scatter of the next, the first and the last beyond it).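

In this assay, the change from benzylsulfanyl to (3-chlorobenzyl)sulfanyl gives a number 4.6 percentage points lower from compound 3 to compound 4 (within the scatter). Going by these compounds alone, this is the first comparison in which the benzyl group changes while the rest of the molecule stays fixed, so it isolates a single substitution on that aromatic ring. On this reading, compound 4 cannot be told apart from compound 3, and adding chloro at this position leaves the inhibition at the dose given without a detectable change; no measurement here offers a reason for that result.

The compounds shown leave open whether this insensitivity extends beyond a single chlorine atom, since an amine or a carboxylic acid on the same aromatic ring might move the number beyond the scatter, as might a longer chain in place of the benzyl group. They also leave open whether chloro elsewhere on that ring would behave in the same way, and a reading at one dose cannot show whether a difference in potency lies hidden between compound 3 and compound 4.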